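Changing One Stereocentre in a Cytotoxic Lactone Series

A few compounds are considered here, and "the series" means these few. Any claim that something is new, unique, unknown or untested is made for them only; others in the source may bear on it.

Measured in a functional assay on WiDr cells (Homo sapiens) for cytotoxicity, read by MTT assay; a lower number here means that less compound is needed, a higher number that more compound is needed for the effect:
- Compound 1 `C=C1CC/C=C(\C)[C@H](OC(C)=O)[C@@H]2OC(=O)C(=C)[C@H]2C[C@H](O)[C@@]2(C)CC[C@@H]1O2`: 3.2 ug/mL
- Compound 2 `C=C1C(=O)O[C@H]2C/C(C)=C/CCC(=C)[C@H]3CC[C@@](C)(O3)[C@@H](O)C[C@H]12`: 1.2 ug/mL

Of these two, compound 2 has the lower number, so less of it is needed for the effect, and its gap to compound 1 lies beyond the usual scatter. Compound 3 `C=C1CC/C=C(\C)C[C@@H]2OC(=O)C(=C)[C@H]2C[C@H](O)[C@@]2(C)CC[C@@H]1O2` has not yet been measured. Set against compound 2, it shows (the two compounds have the same atoms and bonds and differ only in configuration as drawn: 1 of 6 stereo elements differ; a stereocentre at a saturated ring carbon is drawn R in compound 2 and S in compound 3). Nothing leaves and nothing enters. Among the measured compounds shown here, no measured pair here shows what such a change does, so a shift in either direction remains possible and the range must stay wide. The estimate starts from compound 2 at 1.2 ug/mL. The expected change is a 1.3-fold higher number from compound 2 to compound 3 (0.10 log units; within the scatter), a step not expected to lie beyond the scatter in this assay. For compound 3 the estimated value is 1.5 ug/mL, expected to fall between 0.5 ug/mL and 5 ug/mL.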

Compound 3, concentration for half-maximal effect: 1.8 ug/mL
For compound 3 the middle estimate is 1.2-fold (0.08 log units) below the measured one, and the stated range covers the measured number.
By their numbers in this assay, from the lowest: compounds 2, 3 and 1 (each within the scatter of the next, the first and the last beyond it).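

Turning this one stereocentre at a saturated ring carbon from R to S gives a 1.5-fold higher number from compound 2 to compound 3 (0.18 log units; within the scatter) in this assay, the first measured case of such a change here, and it cannot be told apart from the ordinary spread of repeated measurements. The step can be tied to that single stereocentre and nothing else, on this ground: the fact that compounds 2 and 3 differ only in the configuration as drawn. Hydrogen in place of acetoxy on a saturated ring carbon, the other single change now readable, gives a 1.8-fold lower number from compound 1 to compound 3 (0.25 log units; within the scatter), so in this assay the acetoxy group can be taken away without a shift beyond that spread.

As far as these compounds go, it remains open whether an amine or a longer ester such as a benzoate on that same ring carbon would move the number clearly. From the compounds shown here alone, whether inverting any of the other stereocentres would do so also remains open.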